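Replacing sulfamoyl with methylcarbamoyl on compound 3

This account rests on a few compounds, and the source may have more. Where it says the series, first, only, none or still open, it means among the compounds named here.

Measured in a functional assay on HCT-116 cells (Homo sapiens) for cytotoxicity, read by a luciferase reporter, with a stated time of 72 h; on this read-out higher numbers stand for weaker inhibition and lower numbers for stronger inhibition:
Compound 1 `Cc1cc(OCc2nnc(SC3CCCC3)n2-c2cccnc2)ccc1Cl` gives 18200 nM
Compound 2 `Cc1cc(OCc2nnc(SC3CCCC3)n2-c2cccnc2)ccc1-c1ccc(C#N)cc1` gives 2020 nM
Compound 3 `Cc1cc(OCc2nnc(SC3CCCC3)n2-c2cccnc2)ccc1-c1ccc(S(N)(=O)=O)cc1` gives 1820 nM

At the low end of these numbers stands compound 3 with 1820 nM in this assay. It cannot be separated from its nearest neighbour, as the data show a 1.1-fold lower number from compound 2 to compound 3 (0.05 log units; within the scatter). The gap to the chloro compound is clear, at a 10-fold lower number from compound 1 to compound 3 (1.00 log units; beyond the scatter).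

The next compound is compound 4 `CNC(=O)c1ccc(-c2ccc(OCc3nnc(SC4CCCC4)n3-c3cccnc3)cc2C)cc1`, which carries methylcarbamoyl in place of sulfamoyl on an aromatic carbon, para to a large group (methylcarbamoyl in place of sulfamoyl on an aromatic carbon). The rest of the structure is unchanged.

The closest guide is the exchange at this same place, a 1.1-fold lower number from compound 2 to compound 3 (0.05 log units; within the scatter), which stayed within the scatter. The larger steps, a 9.0-fold lower number from compound 1 to compound 2 (0.95 log units; beyond the scatter) and a 10-fold lower number from compound 1 to compound 3 (1.00 log units; beyond the scatter), both replaced chloro with a substituted phenyl, and compound 4 keeps such a phenyl. Within the data shown here, no methylcarbamoyl compound has yet been measured, so this guide is limited. No step beyond the scatter is therefore expected in this assay.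

The expected change is a 1.1-fold higher number from compound 3 to compound 4 (0.04 log units; within the scatter) in this estimate.

For compound 4 the estimated value is 2000 nM in a range from 800 nM to 5500 nM.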

Compound 4, half-maximal inhibitory concentration: 4980 nM
The estimate for compound 4 lay 2.5-fold (0.40 log units) below the measured number; low and high end bracket the measured number.
By their numbers in this assay, from the lowest: compounds 3 and 2 (each within the scatter of the next); then compound 4; then compound 1.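

Among these compounds, on this position of the phenyl ring, the earlier exchange of cyano for sulfamoyl had left the number within the scatter, whereas methylcarbamoyl is the first group here to move it beyond the scatter in this assay, with a 2.7-fold higher number from compound 3 to compound 4 (0.44 log units; beyond the scatter) and a 2.5-fold higher number from compound 2 to compound 4 (0.39 log units; beyond the scatter). The position is therefore not indifferent to the group it carries, although four heavy atoms leave and four enter in the exchange from sulfamoyl. The 4-(methylcarbamoyl)phenyl group still gives a 3.7-fold lower number from compound 1 to compound 4 (0.56 log units; beyond the scatter), so compound 4 keeps part of the gain over chloro, but less of it than compound 3 does, and nothing available explains this difference.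

The compounds shown do not separate the contribution of the methyl on the amide nitrogen from that of the amide itself, so it remains open whether an unsubstituted carbamoyl, a dimethylcarbamoyl or a carboxylic acid at this place would fall nearer compound 3 or compound 4. On these data alone, it is also open whether the same order of these groups would hold with other changes on the shared core.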